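Side chain on sulfur cut back: compound 2 to compound 3

The compounds below may be only part of what the source reports. "The series", "measured", "known", "first", "only" and "open" are said of these compounds alone.

Measured so far in a functional assay on PC-9 cells (Homo sapiens) for inhibition, read by MTT assay, with a stated time of 72 h; a higher number here means a weaker inhibitor, a lower number a stronger inhibitor:
compound 1 `Cc1cc(Nc2cc(-c3ccccc3)[nH]n2)n2nc(SCC3CCCCC3)nc2n1`: > 50000 nM (a limit)
compound 2 `Cc1cc(Nc2cc(-c3ccccc3)[nH]n2)n2nc(SCCCc3ccccc3)nc2n1`: 5030 nM

Within the data shown here, compound 2 carries the only actual number so far, and the value for compound 1 is a limit. The next change leads to compound 3 `C=CCSc1nc2nc(C)cc(Nc3cc(-c4ccccc4)[nH]n3)n2n1`, and it reads vinyl in place of phenethyl on a saturated chain carbon bound to a sulfur, or 3-phenylpropyl to allyl when cut one bond further out.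

Among the measured compounds shown here, one measured step bears on this, at the same place: an at least 9.9-fold lower number from compound 1 to compound 2 (0.99 log units; beyond the scatter), beyond the scatter, with phenethyl in place of cyclohexyl. Its size is a bound only, as compound 1 sits at the limit of > 50000 nM in this assay, at which 1 of the 2 values shown sits. For the measured compounds named here, that step shows the number in this assay moving widely with this side chain, while no measured step covers a chain without a ring. A move to a higher number, beyond the scatter, is therefore expected in this assay. The expected step is a 4.0-fold higher number from compound 2 to compound 3 (0.60 log units; beyond the scatter). For compound 3 the estimated value is 20000 nM, with an expected range of 6000 nM to 60000 nM.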

Compound 3, half-maximal inhibitory concentration: > 50000 nM
Compound 3: a limit, no number; the forecaster's own chance of this, stated with the estimate: 40%; middle value at least 2.5-fold (0.39 log units) away from the limit.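

In this assay, replacing phenethyl with vinyl on a saturated chain carbon bound to a sulfur gives an at least 9.9-fold higher number from compound 2 to compound 3 (0.99 log units; beyond the scatter). Compound 3 gives > 50000 nM, which is a limit, so the size of this step is a bound only. Compound 3 shows that a short chain without a ring, like the cyclohexyl group of compound 1, fails to give a measurable number, leaving compound 2, with its six-membered aromatic ring of carbon only, as the sole compound shown to do so; the step between compound 1 and compound 3 cannot be read, as both values are limits.

Still open, as far as these compounds go, is how much of the chain in compound 2 matters: a benzyl group, a 4-phenylbutyl group or a long chain without a ring could separate the part played by the phenyl ring from that of chain length, and a terminal amine or carboxylic acid would test other end groups. How far each change at this position moves the number also stays unresolved, as the only measured number belongs to compound 2 and the other values sit at a limit: the limit of > 50000 nM in this assay, at which 2 of the 3 values shown sit.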